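Iodophenyl hydrazone series: positional change of iodine

A few compounds are considered here, and "the series" means these few. Any claim that something is new, unique, unknown or untested is made for them only; others in the source may bear on it.

Measured so far, in a functional assay on the whole organism for inhibition, with Rattus norvegicus as the target; on this read-out higher numbers stand for an effect only at larger amounts of compound and lower numbers for an effect already at smaller amounts:
Compound 1, `CC1CC/C(=N\Nc2ccccc2Br)c2ncc(C(=O)O)c(=O)n21`: compound 1 gives > 320 umol/kg, which is a limit of this assay and not a number.
Compound 2, `CC1CC/C(=N\Nc2cccc(Br)c2)c2ncc(C(=O)O)c(=O)n21`: compound 2 gives > 320 umol/kg, again a limit and not a number.
Compound 3, `CC1CC/C(=N\Nc2cccc(I)c2)c2ncc(C(=O)O)c(=O)n21`: compound 3 gives 1000 umol/kg.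

For the measured compounds named here, compound 3 thus carries the only number in the set; the other two values sit at the limit of > 320 umol/kg in this assay, at which 2 of the 3 values shown sit. None of the three steps between the measured compounds can be read: a step that the two limits leave unreadable from compound 1 to compound 2, a step that the limit leaves unreadable from compound 1 to compound 3 and a step that the limit leaves unreadable from compound 2 to compound 3 are all left open by the limits, so no step size is known anywhere in the series.

Compound 4, `CC1CC/C(=N\Nc2ccc(I)cc2)c2ncc(C(=O)O)c(=O)n21`, is not yet measured. It differs from compound 3 by 4-iodophenyl in place of 3-iodophenyl on an amine nitrogen; the two share all atoms and differ only in where the iodine sits on the phenyl ring.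

Going by the values given here, no measured step bears on this change, since every step so far is unreadable. Among the compounds with values here, compound 3 is the only anchor, and its value is the only reference for what compound 4 may give. Compound 4 is therefore expected to sit near compound 3, with a 1.1-fold lower number from compound 3 to compound 4 (0.05 log units; within the scatter) taken as no step beyond the scatter, and with a real chance that this assay again reports only a limit. The estimate for compound 4 is 900 umol/kg, within 250 umol/kg to 3200 umol/kg.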

Compound 4, dose for 50% inhibition: > 1000 umol/kg
Compound 4: no number, only a limit; the forecaster's own chance of this, stated with the estimate: 45%; middle value at least 1.1-fold (0.04 log units) from the limit.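

In this assay compound 4 gives > 1000 umol/kg, which is a limit of the assay and not a number. For 4-iodophenyl in place of 3-iodophenyl on an amine nitrogen, the series now has a direction but no size, while the steps linking compound 4 to compound 1 and compound 2 cannot be read: a number no lower from compound 3 to compound 4 (the limit leaves the size open). At this place, 4-iodophenyl therefore brings no gain over 3-iodophenyl in this assay, and compound 3 remains the only compound with a number, with the highest limit in the series now set by compound 4: the limit of > 1000 umol/kg in this assay, at which 1 of the 4 values shown sits.

Going by these compounds, how far compound 4 actually lies from compound 3 stays open, as does the question of whether any of these halogenated phenyl hydrazones would act at much smaller doses. The compounds shown also say nothing about how an unsubstituted phenyl, or a phenyl carrying a methoxy group or an amino group, on the same amine nitrogen would read in this assay.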